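Cyclooctenyl Swapped for Phenethyl on the Piperidine Chain

This account rests on a few compounds, and the source may have more. Where it says the series, first, only, none or still open, it means among the compounds named here.

Three compounds sharing one core were measured in a functional assay on CHO cells for antagonist activity at C-X-C chemokine receptor type 3 (Homo sapiens), read by GTPgammaS binding; on this read-out lower numbers stand for stronger inhibition and higher numbers for weaker inhibition. Compound 1 `O=C(Nc1ccc2ccccc2c1)NC1CCN(C/C2=C/CCCCCC2)CC1` gives 110 nM. Compound 3 `O=C(Nc1ccc(-c2ccccc2)s1)NC1CCN(C/C2=C/CCCCCC2)CC1` gives 108 nM, a number within the scatter of compound 1. Compound 2 `O=C(Nc1cc(F)cc(C(F)(F)F)c1)NC1CCN(C/C2=C/CCCCCC2)CC1` gives 47 nM, a lower number than compound 1 by more than the scatter, so compound 1 stands highest of the three. Compound 4 `O=C(Nc1ccc2ccccc2c1)NC1CCN(CCCc2ccccc2)CC1` differs from compound 1 by phenethyl in place of cyclooct-1-en-1-yl on a saturated chain carbon bound to an amine nitrogen in a ring. For the measured compounds named here, no measured pair shows this change, so its size is not known from the data. The step of a 3.6-fold higher number from compound 1 to compound 4 (0.56 log units; beyond the scatter) is expected to go toward weaker inhibition and beyond the scatter. Compound 4 is therefore estimated at 400 nM, with a range from 120 nM to 1500 nM.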

Compound 4, inhibition constant: 2200 nM
Beside the measured number, compound 4's estimate is 5.5-fold (0.74 log units) below it, outside the stated range (above it).
By their numbers in this assay, from the lowest: compound 2; then compounds 3 and 1 (each within the scatter of the next); then compound 4.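

In this assay, the group on a saturated chain carbon bound to an amine nitrogen in a ring proves to matter strongly: phenethyl in place of cyclooct-1-en-1-yl gives a 20-fold higher number from compound 1 to compound 4 (1.30 log units; beyond the scatter), a large step towards weaker inhibition. The earlier compounds shown here all carry cyclooct-1-en-1-yl here and differ only at the other end of the urea, so they could not show this. The two groups hold the same number of heavy atoms, all carbon, so that count alone does not set the result, and nothing at hand explains the step.

On these data alone, it remains open whether a saturated cyclooctyl or a cyclohexyl group would keep the inhibition of compound 1. As far as these compounds go, it is also open whether the same change would cost as much on the cores of compound 2 and compound 3.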